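Chloro on the benzyloxy phenyl of compound 1

A few compounds are considered here, and "the series" means these few. Any claim that something is new, unique, unknown or untested is made for them only; others in the source may bear on it.

For the measured compounds named here, compound 1 `O=C1CSc2cc(OCc3ccccc3)ccc2N1` is the lower of the two numbers so far in an assay on isolated protein for inhibition of Amine oxidase [flavin-containing] B (Homo sapiens), read by fluorescence and spectrophotometry, with a stated time of 20 min; on this read-out lower numbers stand for stronger inhibition and higher numbers for weaker inhibition: compound 1 gives 71 nM. Going by the values given here, its only measured neighbour is compound 2 `COc1ccc2c(c1)SCC(=O)N2`, which in this assay gives 42600 nM; the step of a 600-fold higher number from compound 1 to compound 2 (2.78 log units; beyond the scatter) arises from hydrogen in place of phenyl on a saturated chain carbon bound to an oxygen on an aromatic ring. The phenyl on the chain therefore carries most of the inhibition seen for compound 1.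

Compound 3 `O=C1CSc2cc(OCc3ccc(Cl)cc3)ccc2N1` keeps that phenyl and differs from compound 1 only by chloro in place of hydrogen on an aromatic carbon, the chloro sitting para to a large group on a six-membered aromatic ring of carbon only. Among the compounds with values here, no measured step involves substitution on that ring, so the step from compound 1 to compound 2, large as it is, does not bear on this change. With nothing to indicate otherwise, the expectation for compound 3 is a step within the scatter, or at most a modest gain. For compound 3 the estimate in this assay is 50 nM, ranging from 15 nM to 200 nM. This corresponds to an expected step of a 1.4-fold lower number from compound 1 to compound 3 (0.15 log units; within the scatter).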

Compound 3, half-maximal inhibitory concentration: 2.7 nM
For compound 3 the middle estimate is 19-fold (1.27 log units) above the measured one; measured number outside the range, below it.
By their numbers in this assay, from the lowest: compound 3; then compound 1; then compound 2.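

In this assay the phenyl of the benzyloxy group proves to be more than a required piece: the earlier step, a 600-fold higher number from compound 1 to compound 2 (2.78 log units; beyond the scatter), showed only that losing the phenyl costs most of the inhibition, whereas this position on the phenyl also responds strongly to substitution. Chloro in place of hydrogen, para to a large group on that ring, gives a 26-fold lower number from compound 1 to compound 3 (1.42 log units; beyond the scatter), so a change of one chlorine atom on an aromatic carbon moves the number well beyond the scatter. No measurement accompanies this step that could account for it, and its origin stays unassigned.

The compounds shown leave open whether this gain belongs to chloro itself or would also appear with fluoro, bromo, methyl or methoxy at the same place, and whether an amine or a carboxylic acid there would keep any of it. Also open, going by these compounds, is whether chloro on another carbon of that ring, or a second chloro added to compound 3, would move the number further or reverse the gain.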